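Replacing the Acyl Arm of Compound 2: An Expected Outcome

This account rests on a few compounds, and the source may have more. Where it says the series, first, only, none or still open, it means among the compounds named here.

Compound 1, `COc1ccc(C2CC(c3ccc(OC)c(OC)c3)=NN2)c(OC)c1`, gives 38% in a functional assay on the whole organism (strain albino) for inhibition, with Rattus norvegicus as the target, read by paw edema, with stated times of 30 min and 1 h, at a dose of 100 mg/kg by the oral route; on this read-out lower numbers stand for less inhibition and higher numbers for more inhibition at the one dose given (going by the name of the read-out).
Compound 2, `COc1ccc(C2CC(c3ccc(OC)c(OC)c3)=NN2C(=O)C(C)Br)c(OC)c1`, gives 58%.
Compound 3, `COc1ccc(C2=NN(C(=O)C(C)Br)C(c3c(Cl)cccc3Cl)C2)cc1OC`, gives 51%.

For the measured compounds named here, of the three numbers measured so far, compound 2 stands highest. Its nearest neighbour is compound 3: the step of a number 7 percentage points lower from compound 2 to compound 3 (within the scatter) lies within the scatter, so the two cannot be ranked against each other. The furthest is compound 1, and the step of a number 20 percentage points higher from compound 1 to compound 2 (beyond the scatter) lies beyond the scatter.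

The next compound, compound 4, `COc1ccc(C2CC(c3ccc(OC)c(OC)c3)=NN2C(=O)CNc2ccc(/C(C)=N/O)cc2)c(OC)c1`, differs from compound 2 at the carbonyl carbon that sits on the ring nitrogen: a group of 12 heavy atoms (9 carbon, 2 nitrogen, 1 oxygen; one six-membered aromatic ring of carbon only) in place of a group of 3 heavy atoms (2 carbon, 1 bromine; no ring), on a carbonyl carbon. Going by the values given here, no measured step alters the group on this carbonyl carbon. The step of a number 20 percentage points higher from compound 1 to compound 2 (beyond the scatter) concerns putting the acyl group onto the ring nitrogen where hydrogen had been, and so bears only loosely on an exchange of one acyl substituent for another. The step of a number 7 percentage points lower from compound 2 to compound 3 (within the scatter) touches a different position altogether and was itself within the scatter. With nothing measured that speaks directly to this change, the expected step is a number 3 percentage points lower from compound 2 to compound 4 (within the scatter), that is, no move beyond the scatter in either direction. The estimate for compound 4 is accordingly 55%, with a range from 40% to 70%.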

Compound 4, a percentage reported as inhibition, in the whole organism at one dose (the size of the read-out at that dose, not a potency): 27%
Beside the measured number, compound 4's estimate is 28 percentage points above it; measured number outside the range, below it.
By their numbers in this assay, from the lowest: compound 4; then compound 1; then compounds 3 and 2 (each within the scatter of the next).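

For the compounds shown here, the group on this carbonyl carbon, whose other neighbour is the amide-type nitrogen in a ring, proves to matter in this assay: exchanging 1-bromoethyl for the group of 12 heavy atoms with its six-membered aromatic ring gives a number 31 percentage points lower from compound 2 to compound 4 (beyond the scatter), the largest step among the compounds so far. The earlier compounds shown here showed a higher number with the 1-bromoethyl carbonyl on that nitrogen, but this result shows that an acyl group there does not by itself bring such a number, since compound 4 gives 27% while compound 1, with hydrogen on the nitrogen, gives 38%. Nothing available explains the step from compound 2 to compound 4.

The exchange alters the size, the ring, the double bond and the hydrogen-bond donors and acceptors together, so the compounds shown do not tell which of these features goes with the step. As far as these compounds go, it also remains open whether a plain methyl, a simple aminomethyl group or a phenylaminomethyl group lacking the oxime on this carbonyl carbon would give a number nearer to that of compound 2 or that of compound 4.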